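The source may hold more compounds than are shown below. What is called first, only, known or untested is meant among the compounds shown, and "the series" means these compounds.

Measured so far:
- compound 1, `Cc1cc(C)cc(C(=O)NCN2CCC(c3cccc[n+]3[O-])CC2)c1`, in a functional assay on HEK293 cells for agonist activity at D(4) dopamine receptor (Homo sapiens), read by FLIPR (a lower number here means that less compound is needed, a higher number that more compound is needed for the effect), gives 90 nM
- compound 2, `O=C(CN1CCC(c2cccc[n+]2[O-])CC1)Nc1ccc(F)cc1F`, in this assay gives 103 nM
- compound 3, `O=C(CN1CCC(c2cccc[n+]2[O-])CC1)Nc1cccc(-c2ccccc2)c1`, in this assay gives 360 nM

Compound 2 holds the second highest of these three numbers. Its value and that of compound 1 lie within the usual scatter of each other, so no order between them can be claimed; compound 3, by contrast, shows a higher number that lies beyond the scatter. The unmeasured compound 4, `O=C(CN1CCC(c2cccc[n+]2[O-])CC1)Nc1cccc(Cl)c1Cl`, keeps the shared core of compound 2 and changes only the aryl group on the amide nitrogen: 2,3-dichlorophenyl in place of 2,4-difluorophenyl on an amide-type nitrogen. For the measured compounds named here, no measured pair shows the effect of such a swap, so the expected step in this assay is none beyond the scatter, with the direction open. For compound 4 the expected value is 100 nM, in the range 35 nM to 300 nM, an expected step of a 1.0-fold lower number from compound 2 to compound 4 (0.01 log units; within the scatter).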

Compound 4, half-maximal effective concentration: 180 nM
Estimate against measurement, compound 4: 1.8-fold (0.26 log units) below; the range from low to high includes it.
By their numbers in this assay, from the lowest: compounds 1, 2, 4 and 3 (each within the scatter of the next, the first and the last beyond it).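

In this assay, for the compounds shown here, this pair gives a 1.7-fold higher number from compound 2 to compound 4 (0.24 log units; within the scatter) and is the first to isolate the aryl group on the amide-type nitrogen. At this position, 2,3-dichlorophenyl in place of 2,4-difluorophenyl therefore leaves the number within the usual scatter. The swap changes both the halogen and where it sits on the ring, yet this one pair cannot separate those two differences. As far as these compounds go, whether the position would also tolerate a phenyl ring carrying a methoxy group or an amine, or a cyclohexyl group in place of the aromatic ring, stays open. No measurement shown here explains the result.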